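Swapping the Other Nitro Group for Bromo

The source may report more compounds than this note shows. Statements on the series, on what has been measured and on what is new or still open speak of the compounds shown alone.

In a functional assay on THP-1 cells (Homo sapiens) for inhibition, read by sulforhodamine B assay, with a stated time of 48 h (on this read-out higher numbers stand for weaker inhibition of growth and lower numbers for stronger inhibition of growth), compound 1 `N#CCC1=C(C#N)CC(c2ccc([N+](=O)[O-])cc2)=C(CC(=O)c2ccc([N+](=O)[O-])cc2)O1` gives 10200 nM. Within the data shown here, this is the lower of the two numbers measured so far, which makes compound 1 the stronger growth inhibitor of the pair. Compound 2 `N#CCC1=C(C#N)CC(c2ccc([N+](=O)[O-])cc2)=C(CC(=O)c2ccc(Br)cc2)O1` gives 26000 nM. Compound 1 carries two 4-nitrophenyl groups, and compound 2 has one of them changed to 4-bromophenyl.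

Compound 3 `N#CCC1=C(C#N)CC(c2ccc(Br)cc2)=C(CC(=O)c2ccc([N+](=O)[O-])cc2)O1` has not yet been measured. It keeps that group as 4-nitrophenyl and changes the other one instead: bromo in place of nitro on an aromatic carbon. In words, this is bromo in place of nitro on an aromatic carbon, the same kind of swap made elsewhere on the molecule.

Among the measured compounds shown here, only one measured step bears on this change: a 2.5-fold higher number from compound 1 to compound 2 (0.41 log units; beyond the scatter). A single modest step at another site is thin evidence, but it points towards a higher number in this assay, not a lower one. The expected change is of similar size: a 2.0-fold higher number from compound 1 to compound 3 (0.29 log units; within the scatter). For compound 3 the estimated value is 20000 nM, with an expected range of 8000 nM to 50000 nM.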

Compound 3, concentration for 50% growth inhibition: 12900 nM
The estimate for compound 3 lay 1.6-fold (0.19 log units) above the measured number; the measured number falls inside the stated range.
By their numbers in this assay, from the lowest: compounds 1, 3 and 2 (each within the scatter of the next, the first and the last beyond it).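

In this assay, putting bromo in place of nitro at this position gives a 1.3-fold higher number from compound 1 to compound 3 (0.10 log units; within the scatter), so on this evidence the nitro group here is not needed to keep growth inhibition at the level of compound 1. The same kind of swap on the other 4-nitrophenyl group gave a 2.5-fold higher number from compound 1 to compound 2 (0.41 log units; beyond the scatter), a step that lies beyond the usual scatter, so the two sites need not be treated as interchangeable and a result at one cannot simply be carried over to the other. No measurement available here explains why the two swaps read differently.

The compounds shown leave open how this position responds to other groups in place of nitro, such as an amine, a carboxylic acid or a methoxy group, and whether a plain phenyl with nothing at that place would serve as well. They also leave open what happens when both 4-nitrophenyl groups become 4-bromophenyl in a single molecule, which would show whether the two swaps act independently.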